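The source may hold more compounds than are shown below. What is called first, only, known or untested is meant among the compounds shown, and "the series" means these compounds.

Measured in an ADME assay on Vero cells (Chlorocebus sabaeus) for cytotoxicity, read by neutral red uptake, with a stated time of 3 days; a lower number here means that less compound is tolerated, a higher number that more compound is tolerated:
- compound 1 `CC(CN(C)C)NC(=O)c1cc(C(C)C)nc2c1cnn2C(C)C`: 117000 nM
- compound 2 `CC(C)n1ncc2c(C(=O)NCCN)cc(C(C)(C)C)nc21`: 23000 nM
- compound 3 `Cc1cc(C(=O)NC2CN(C)C2)c2cnn(C(C)C)c2n1`: > 300000 nM (a limit of the assay, not a number)

Compound 3 has only a limit in this assay, so its true position is not known: the limit of > 300000 nM in this assay, at which 1 of the 3 values shown sits. Compound 1 and compound 2 both have numbers, and the value of compound 2 is the lower of the two.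

The next compound to be read is compound 4 `Cc1cc(C(=O)NCCN)c2cnn(C(C)C)c2n1`. It carries 2-aminoethyl in place of 1-methylazetidin-3-yl on an amide-type nitrogen. Within the data shown here, no measured pair isolates this change, so the expectation rests on indirect evidence. Among the measured compounds shown here, compound 2 is the only measured compound with 2-aminoethyl on that nitrogen, and it gives 23000 nM. The rest of its structure differs from that of compound 4, so it serves only as a loose guide. A moderate move towards less compound tolerated in this assay is therefore expected, and its size is uncertain. The expected change is an at least 2.0-fold lower number from compound 3 to compound 4 (0.30 log units; that floor lies within the scatter), and a result that is again only a limit remains possible. For compound 4 the estimate is 150000 nM, with an expected range of 50000 nM to 300000 nM.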

Compound 4, half-maximal cytotoxic concentration: > 300000 nM
Compound 4 ended at the assay's limit; the forecaster's own chance of this, stated with the estimate: 30%; middle value at least 2.0-fold (0.30 log units) away from the limit.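

In this assay, replacing 1-methylazetidin-3-yl with 2-aminoethyl on the amide-type nitrogen gives compound 4, whose > 300000 nM is a limit of the assay and not a number, so 2-aminoethyl on this nitrogen does not by itself bring a measurable value on the methyl-bearing core. Compound 2 carries the same 2-aminoethyl and differs only in having tert-butyl where compound 4 has methyl on an aromatic carbon, and that single change gives an at least 13-fold higher number from compound 2 to compound 4 (1.11 log units; beyond the scatter), which makes this aromatic position, rather than the amide side chain, the first place in the series with a readable effect. The step for the amide change itself cannot be read because both of its ends are limits: the limit of > 300000 nM in this assay, at which 2 of the 4 values shown sit.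

On these data alone, it remains open whether an intermediate group such as ethyl or cyclopropyl on that aromatic carbon would give a number within the assay's range, and where along that series the drop would begin. Also open, as far as these compounds go, is whether tert-butyl paired with 1-methylazetidin-3-yl, or a longer chain such as 3-aminopropyl on the amide-type nitrogen, would make the amide change readable.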